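One Methoxy Added Twice, on Two Different Cores

The source may hold more compounds than are shown below. What is called first, only, known or untested is meant among the compounds shown, and "the series" means these compounds.

Compound 1 `COc1ccc(C2=N/C(=C\c3cc(Br)cc(Br)c3OC(C)=O)C(=O)n3c(C)nc(=S)n32)cc1OC` and compound 2 `COc1cc(C2=N/C(=C\c3cc(Br)cc(Br)c3OC(C)=O)C(=O)n3c(C)nc(=S)n32)cc(OC)c1OC` share a core and differ in one place: methoxy in place of hydrogen on an aromatic carbon. In a functional assay on MCF7 cells (Homo sapiens) for antiproliferative activity, read by MTT assay, with a stated time of 48 h (a higher number here means a weaker inhibitor, a lower number a stronger inhibitor), compound 1 gives 6840 nM, and compound 2 gives 3070 nM. That change made a 2.2-fold lower number from compound 1 to compound 2 (0.35 log units; beyond the scatter), a step just large enough to count.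

Compound 3 `COc1ccc(C2=N/C(=C\c3cc(Br)cc(Br)c3OC(C)=O)C(=O)NN2c2ccccc2)cc1OC` carries the same 3,4-dimethoxyphenyl group on a different core; how its core differs from that of compound 1 is not broken down here. In this assay compound 3 gives 5390 nM, a number that sits within the usual scatter of that of compound 1 and also of that of compound 2, so no order among these three compounds can be read beyond the one step already named.

Compound 4 `COc1cc(C2=N/C(=C\c3cc(Br)cc(Br)c3OC(C)=O)C(=O)NN2c2ccccc2)cc(OC)c1OC` is what compound 3 becomes when the same change is made: methoxy in place of hydrogen on an aromatic carbon. The surroundings of the change read the same in both pairs, so this is the same change set on another core. Among the measured compounds shown here, the only guide to its effect is the single earlier pair, where the step was a 2.2-fold lower number from compound 1 to compound 2 (0.35 log units; beyond the scatter), and a change on one core need not repeat in full on another. The step from compound 3 to compound 4 is therefore expected to be a 1.9-fold lower number from compound 3 to compound 4 (0.27 log units; within the scatter). Compound 4 is estimated at 2900 nM in this assay. Its likely range is expected to run from 1500 nM to 6500 nM.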

Compound 4, half-maximal inhibitory concentration: 350 nM
The estimate for compound 4 lay 8.3-fold (0.92 log units) above the measured number; measured number outside the range, below it.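

On the core of compound 3, going from 3,4-dimethoxyphenyl to 3,4,5-trimethoxyphenyl by adding one methoxy group gives a large gain in this assay: a 15-fold lower number from compound 3 to compound 4 (1.19 log units; beyond the scatter). The direction of the change carried over from one core to the other, since the number fell on both, but its size did not, so the small step on the first core proved a poor guide to the step on the second: the same change on two cores in this assay, a 2.2-fold lower number (0.35 log units; beyond the scatter) from compound 1 to compound 2 and a 15-fold lower number (1.19 log units; beyond the scatter) from compound 3 to compound 4, 6.9-fold (0.84 log units) apart, beyond the scatter of two such steps. These two pairs show that the core can strongly alter what this change does, yet they do not show which part of the core matters or why the steps differ, and two pairs are too few to predict the size of the step on a further core.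

The compounds shown leave open whether the larger step on the core of compound 3 belongs to methoxy alone or would also appear with another group in the same place, such as an ethoxy group, a hydroxyl group or an amine. They also leave open whether the gap between the two steps would persist if the acetate ester on the dibrominated ring were replaced by a hydroxyl group.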